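This account rests on a few compounds, and the source may have more. Where it says the series, first, only, none or still open, it means among the compounds named here.

Measured so far:
Compound 1, `Cc1cccnc1-c1nc2ccccc2[nH]1`: in a functional assay on the whole organism with Rattus norvegicus as the target, read by paw edema, with a stated time of 3 h, at a dose of 100 mg/kg by the oral route (a lower number here means less inhibition, a higher number more inhibition at the dose given (going by the name of the read-out)), compound 1 gives 17%.
Compound 2, `Cc1cccc(-c2nc3ccccc3[nH]2)n1`: in this assay compound 2 gives 44%.

Compound 2 stands highest of the two numbers recorded; its nearest neighbour, compound 1, is lower by a gap that lies beyond the usual scatter of this kind of measurement. The two share the same core and the same methyl group, and the two values show how much the result can shift within that small pair.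

Compound 3, `Oc1cccc(-c2nc3ccccc3[nH]2)n1`, has not yet been measured in this assay. Its difference from compound 2 is this: hydroxy in place of methyl on an aromatic carbon. Among the compounds with values here, no step between measured compounds reports what a change of this kind does to the read-out, so the expectation for compound 3 rests on the value of compound 2 alone and on the single substitution. A moderate fall, or no change beyond the scatter, is the expectation here; the estimated step is a number 14 percentage points lower from compound 2 to compound 3 (beyond the scatter). Compound 3 is therefore expected to give about 30% in this assay, with the estimate ranging from 10% to 55%.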

Compound 3, a percentage reported as inhibition, in the whole organism at one dose (the size of the read-out at that dose, not a potency): -7%
Beside the measured number, compound 3's estimate is 37 percentage points above it; measured number below the stated range.
By their numbers in this assay, from the lowest: compound 3; then compound 1; then compound 2.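

In this assay, within the data shown here, hydroxy in place of methyl on an aromatic carbon next to the ring nitrogen gives a number 51 percentage points lower from compound 2 to compound 3 (beyond the scatter), the first step between measured compounds that differ in one place. This shows that the position is far from indifferent to what it carries: exchanging a single carbon for a single oxygen, with one hydrogen-bond donor and one hydrogen-bond acceptor entering, is enough to remove all the inhibition seen with compound 2 at this dose. The result also shows that the read-out can go below zero within this small set, since compound 3 gives -7%. Nothing measured here bears on what lies behind so large a fall.

Going by these compounds, whether an amine, a methoxy group or a longer chain such as ethyl at this position would stay close to compound 2 or fall towards compound 3 remains open. On these data alone, it is also open whether hydroxy would cost as much on another carbon of the ring, as this single pair speaks only for one position on one core.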